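A Larger Amine Ring on Compound 2

The source may hold more compounds than are shown below. What is called first, only, known or untested is meant among the compounds shown, and "the series" means these compounds.

Of the compounds shown here, two have been measured in a functional assay on NCI-H661 cells (Homo sapiens) for cytotoxicity, read by WST assay, with a stated time of 72 h; a higher number here means a weaker inhibitor, a lower number a stronger inhibitor. Compound 1 `COc1cc2c(Nc3nc4ccc(C(=O)Nc5c(C)cc(C)cc5C)cc4s3)ncnc2cc1OCCCN1CCC(C)CC1` gives 7700 nM, while compound 2 `COc1cc2c(Nc3nc4ccc(C(=O)Nc5c(C)cccc5Cl)cc4s3)ncnc2cc1OCCCN1CCCC1` gives 45500 nM, the higher of the two numbers and beyond the scatter from compound 1. Compound 3 `COc1cc2c(Nc3nc4ccc(C(=O)Nc5c(C)cccc5Cl)cc4s3)ncnc2cc1OCCCN1CCC(C)CC1` differs from compound 2 in one place: 4-methylpiperidin-1-yl in place of pyrrolidin-1-yl on a saturated chain carbon, three bonds along the chain from an oxygen on an aromatic ring. Among the compounds with values here, no measured pair shows this change alone, so its size is not known here. Because compound 1 with its 4-methylpiperidin-1-yl group gives 7700 nM, the step of a 2.5-fold lower number from compound 2 to compound 3 (0.40 log units; beyond the scatter) is expected to lower the number, though by less than the gap separating compound 1 from compound 2, as the amide part also differs. Compound 3 is therefore estimated at 18000 nM, with a range from 6000 nM to 50000 nM.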

Compound 3, half-maximal inhibitory concentration: 7900 nM
For compound 3 the middle estimate is 2.3-fold (0.36 log units) above the measured one; low and high end bracket the measured number.
By their numbers in this assay, from the lowest: compounds 1 and 3 (each within the scatter of the next); then compound 2.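

In this assay, within the data shown here, the change to 4-methylpiperidin-1-yl from pyrrolidin-1-yl on this chain now has a size of its own, a 5.8-fold lower number from compound 2 to compound 3 (0.76 log units; beyond the scatter) and no longer rests on compounds that also differ in the amide part. With 4-methylpiperidin-1-yl held fixed, 2-chloro-6-methylphenyl in place of 2,4,6-trimethylphenyl on an amide-type nitrogen gives a 1.0-fold higher number from compound 1 to compound 3 (0.01 log units; within the scatter) so this amide change stays within the scatter. Nothing available here explains either step.

Going by these compounds, whether the step belongs to the larger ring or to its methyl stays open, as does how piperidin-1-yl without the methyl, or morpholin-4-yl, would read on the same chain.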